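The source may report more compounds than this note shows. Statements on the series, on what has been measured and on what is new or still open speak of the compounds shown alone.

Of the compounds shown here, two have so far been measured in an assay on Sf21 cells for inhibition of cytochrome c oxidase subunit 2 (Homo sapiens), read by spectrophotometry, with a stated time of 5 min; a lower number here means a stronger inhibitor, a higher number a weaker inhibitor. Compound 1 `COc1ccc(C(=O)CC2CC(=O)N(c3ccc(S(N)(=O)=O)cc3)C2=O)cc1` gives 2100 nM in this assay, the lower of the two numbers. Compound 2 `O=C1CCCCC1C1CC(=O)N(c2ccccc2)C1=O` gives 45100 nM in this assay; the gap between these two values lies well beyond the scatter of repeated measurements, so compound 1 stands clearly as the stronger inhibitor of the pair. Compound 3 `NS(=O)(=O)c1ccc(N2C(=O)CC(CC(=O)c3ccccn3)C2=O)cc1` has not yet been measured. It differs from compound 1 in one place: pyridin-2-yl in place of 4-methoxyphenyl on a carbonyl carbon. The carbonyl carbon and the rest of the shared core stay the same. Among the measured compounds shown here, no measured pair shows what this exchange does, so the expectation rests on compound 1 alone. The exchange is expected to move the number only modestly, a slight loss being somewhat more likely than a gain, which amounts to an expected step of a 1.7-fold higher number from compound 1 to compound 3 (0.22 log units; within the scatter). Compound 3 is therefore expected to give about 3500 nM, within a range from 1000 nM to 12000 nM.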

Compound 3, half-maximal inhibitory concentration: 8940 nM
Estimate against measurement, compound 3: 2.6-fold (0.41 log units) below, within the range that was stated.
By their numbers in this assay, from the lowest: compound 1; then compound 3; then compound 2.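

In this assay, the group on this carbonyl carbon is not freely interchangeable: pyridin-2-yl in place of 4-methoxyphenyl gives a 4.3-fold higher number from compound 1 to compound 3 (0.63 log units; beyond the scatter), a modest but real loss of inhibition. Of the two groups seen here, 4-methoxyphenyl therefore gives the stronger inhibitor, while the pyridin-2-yl compound still remains measurable in this assay. No measurement here accounts for the loss.

This single exchange replaces a ring carbon with nitrogen and also removes the methoxy group, so the two changes cannot be separated. A plain phenyl group would help to pull them apart, while pyridin-3-yl, pyridin-4-yl or a saturated cyclohexyl ring would show whether the placing of the nitrogen or the aromatic ring itself matters.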